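The source may hold more compounds than are shown below. What is called first, only, known or untested is meant among the compounds shown, and "the series" means these compounds.

For the measured compounds named here, compound 2 `O=C1c2cc(COc3ccccc3)nn2CCN1c1ccccn1` stands at the lower of the two numbers so far: in a functional assay on HEK293 cells for positive allosteric modulation of metabotropic glutamate receptor 5 (Homo sapiens), read by calcium flux (on this read-out higher numbers stand for larger maximal responses and lower numbers for smaller maximal responses), compound 2 gives 69%, while compound 1 `O=C1c2cc(COc3ccccc3)nn2CCN1c1ccc(F)c(F)c1` gives 81%. Going by the values given here, the only measured step at the amide-type ring nitrogen is a number 12 percentage points lower from compound 1 to compound 2 (beyond the scatter), a modest one. Compound 3 `O=C1c2cc(COc3ccccc3)nn2CCN1c1ccncc1` differs from compound 2 by pyridin-4-yl in place of pyridin-2-yl on an amide-type nitrogen in a ring. Among the compounds with values here, no measured step exchanges pyridin-2-yl for pyridin-4-yl, so for compound 3 a step within the scatter, without a clear direction, is expected, namely a number 1 percentage points higher from compound 2 to compound 3 (within the scatter). For compound 3 the expected value in this assay is 70%, with a range from 55% to 85%.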

Compound 3, largest response reached (Emax), in percent of the reference or control that the assay uses: 72%
Beside the measured number, compound 3's estimate is 2 percentage points below it; measured number inside the range.
By their numbers in this assay, from the lowest: compounds 2, 3 and 1 (each within the scatter of the next, the first and the last beyond it).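

In this assay, the step of a number 3 percentage points higher from compound 2 to compound 3 (within the scatter) shows that pyridin-4-yl and pyridin-2-yl on the amide-type ring nitrogen cannot be told apart on this read-out. Against 3,4-difluorophenyl, pyridin-4-yl gives a number 9 percentage points lower from compound 1 to compound 3 (within the scatter) and pyridin-2-yl gives a number 12 percentage points lower from compound 1 to compound 2 (beyond the scatter), so only the latter exchange clears the scatter, although the two pyridines do not separate from each other. No evidence on the reason for these numbers is at hand. Open, as far as these compounds go, is how pyridin-3-yl or cyclohexyl on this nitrogen would read.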